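A few compounds are considered here, and "the series" means these few. Any claim that something is new, unique, unknown or untested is made for them only; others in the source may bear on it.

Compound 1 `CC(C)c1ccccc1NC(=O)N[C@H](C)c1ccccc1`: 103%
Compound 2 `C[C@@H](NC(=O)Nc1ccccc1C(C)(C)C)c1ccccc1`: 100%
Compound 3 `C[C@@H](NC(=O)Nc1ccccc1C(F)(F)F)c1ccccc1`: 99%

In an ADME assay on the whole organism with Oryza sativa as the target, tested at 0.1 uM (a lower number here means a stronger effect, a higher number a weaker effect of the compound at the concentration tested), compound 3 gives 99%, the lowest of the three numbers, yet its steps to compound 2 and compound 1 stay within the scatter; compound 2 stands nearest at 100% and compound 1 furthest at 103%. Compound 4 `C[C@@H](NC(=O)Nc1ccccc1F)c1ccccc1` has not yet been measured. It differs from compound 3 in one place: fluoro in place of trifluoromethyl on an aromatic carbon. Among the measured compounds shown here, two measured steps bear on this, since both exchange the group on the same aromatic carbon: a number 4 percentage points lower from compound 1 to compound 3 (within the scatter) and a number 1 percentage points lower from compound 2 to compound 3 (within the scatter). Neither moved the number beyond the scatter, so for this assay no step beyond the scatter is expected here either. Compound 4 is therefore estimated at 99%, between 91% and 107%, an expected step of no change at the digits printed from compound 3 to compound 4 (within the scatter).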

Compound 4, a percentage reported as activity, at one concentration (the size of the read-out at that concentration, not a potency): 97%
Compound 4: the middle estimate sits 2 percentage points above what was measured, within the range that was stated.
By their numbers in this assay, from the lowest: compounds 4, 3, 2 and 1 (each within the scatter of the next).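

In this assay, compound 4 carries fluoro, a single heavy atom, on this aromatic carbon. The number held within the scatter against all three larger groups: trifluoromethyl (a number 2 percentage points lower from compound 3 to compound 4 (within the scatter)), tert-butyl (a number 3 percentage points lower from compound 2 to compound 4 (within the scatter)) and isopropyl (a number 6 percentage points lower from compound 1 to compound 4 (within the scatter)). Size at this position, across this range of small uncharged groups, therefore shows no readable effect on the read-out. No supporting data bear on this result. Still open, from the compounds shown here alone, is whether an amine or a carboxylic acid on this aromatic carbon would move the number beyond the scatter.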